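Moving the methylsulfanyl group on the urea aryl ring

This account rests on a few compounds, and the source may have more. Where it says the series, first, only, none or still open, it means among the compounds named here.

Compound 1 `O=C(Nc1cccc(C(F)(F)F)c1)N[C@H]1CC[C@H](Oc2cccc(C(F)(F)F)c2)CC1` gives 1300 nM in a functional assay on CRL2813 cells (Homo sapiens) for cytotoxicity, read by sulforhodamine B assay, with a stated time of 5 days; on this read-out lower numbers stand for stronger inhibition and higher numbers for weaker inhibition.
Compound 2 `CSc1ccccc1NC(=O)N[C@H]1CC[C@H](Oc2ccc(F)cc2)CC1` gives > 20000 nM in this assay.
Compound 3 `O=C(Nc1cccc(C(F)(F)F)c1)N[C@H]1CC[C@H](Oc2ccccc2C(F)(F)F)CC1` gives 1400 nM in this assay.

Among these three, compound 2 stands apart: its result in this assay is only a limit of the assay, not a number, (the limit of > 20000 nM in this assay, at which 1 of the 3 values shown sits). Compound 1 and compound 3 both give numbers, and the step of a 1.1-fold higher number from compound 1 to compound 3 (0.03 log units; within the scatter) shows that swapping the position of a trifluoromethyl group on the ether-linked ring changes little.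

Compound 4 `CSc1cccc(NC(=O)N[C@H]2CC[C@H](Oc3ccc(F)cc3)CC2)c1` differs from compound 2 by 3-(methylsulfanyl)phenyl in place of 2-(methylsulfanyl)phenyl on an amide-type nitrogen. Among the measured compounds shown here, no measured step touches the urea-side ring, so the only measured step, from compound 1 to compound 3, bears on it only loosely, and it was within the scatter. Since compound 2 shows only a limit, the size of the step to compound 4 cannot be fixed from the numbers. Compound 4 is therefore expected, with wide uncertainty, to give 15000 nM (range 4000 nM to 40000 nM), corresponding to an estimated step of an at least 1.3-fold lower number from compound 2 to compound 4 (0.12 log units; that floor lies within the scatter).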

Compound 4, half-maximal inhibitory concentration: 11100 nM
Estimate against measurement, compound 4: 1.4-fold (0.13 log units) above; low and high end bracket the measured number.
By their numbers in this assay, from the lowest: compounds 1 and 3 (each within the scatter of the next); then compound 4. At a limit, above all of these: compound 2.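

Compound 2 gives only a limit of the assay, not a number: the limit of > 20000 nM in this assay, at which 1 of the 4 values shown sits. Compound 4 gives a measured number, so this move of the methylsulfanyl group on the urea aryl ring can be given a minimum size in this assay, read as an at least 1.8-fold lower number from compound 2 to compound 4 (0.25 log units; that floor lies within the scatter). Going by these compounds, that minimum alone does not establish a real gain, and the true size of the step stays unknown, but 3-(methylsulfanyl)phenyl on the amide-type nitrogen gives a value that can be read, where 2-(methylsulfanyl)phenyl does not.

The compounds shown leave open whether the same move would give a similar result with a different ring on the ether oxygen. They also leave open how a methoxy group or an amine would compare in place of the methylsulfanyl group.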